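Swapping a Bromo for a Benzyloxy on a Weak Cytotoxic Scaffold

This account rests on a few compounds, and the source may have more. Where it says the series, first, only, none or still open, it means among the compounds named here.

Compound 1 `Cc1cc(O)c(C(=O)/C=C/c2ccc(OCc3ccccc3)cc2)c(-c2ccccc2)c1C(=O)/C=C/c1ccc(OCc2ccccc2)cc1` is the reference point: in a functional assay on HeLa cells (Homo sapiens) for cytotoxicity, read by MTT assay, with a stated time of 24 h (on this read-out higher numbers stand for weaker inhibition and lower numbers for stronger inhibition), compound 1 gives 20000 nM. Compound 2 `Cc1cc(O)c(C(=O)/C=C/c2ccc(OCc3ccccc3)cc2)c(-c2ccc(Br)cc2)c1C(=O)/C=C/c1ccc(OCc2ccccc2)cc1` differs from it by a bromo group on the pendant ring, and in this assay compound 2 gives "not active" (no number reported), so no single number is available for where compound 2 stands. Compound 3 `Cc1cc(O)c(C(=O)/C=C/c2ccc(OCc3ccccc3)cc2)c(-c2ccc(OCc3ccccc3)cc2)c1C(=O)/C=C/c1ccc(OCc2ccccc2)cc1` carries a (benzyloxy in place of bromo on an aromatic carbon). Among the compounds with values here, with no measured step connecting the pair, the change from compound 2 to compound 3 is taken as one that stays close to the weak level seen so far, with no step expected beyond the usual scatter. Compound 3 is expected to give about 30000 nM in this assay, with a likely range from 10000 nM to 100000 nM.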

Compound 3, half-maximal inhibitory concentration: "not active" (no number reported)
The entry for compound 3 holds no number; there is nothing to compare the estimate with.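

Within the data shown here, compound 2 and compound 3 are both reported as "not active" with no number, so no step between them can be read. Nothing available explains this result. Going by these compounds, whether benzyloxy in place of bromo changes cytotoxicity at all remains open.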